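This account rests on a few compounds, and the source may have more. Where it says the series, first, only, none or still open, it means among the compounds named here.

Compound 1 `Nc1nc(Cl)c2ncn(Cc3ccccc3CCl)c2n1` and compound 2 `ClCc1cccc(Cn2cnc3nc(Cl)nc(Cl)c32)c1` have both been tested in a functional assay on MOLT-4 cells (Homo sapiens) for cytotoxicity, read by sulforhodamine B assay, with a stated time of 48 h; a lower number here means a stronger inhibitor of growth, a higher number a weaker inhibitor of growth. In this assay compound 1 gives 5130 nM, the highest of the two numbers, while compound 2 gives 1040 nM, a gap beyond the usual scatter. Compound 3 `ClCc1ccccc1Cn1cnc2c(Cl)nc(Cl)nc21` has not yet been measured; it differs from compound 1 by chloro in place of amino on an aromatic carbon. Because compound 2, which also carries chloro rather than amino on the shared core, gives 1040 nM in this assay, a lower number is expected for compound 3. The expected step is a 3.4-fold lower number from compound 1 to compound 3 (0.53 log units; beyond the scatter). Compound 3 is estimated at 1500 nM, within a range from 500 nM to 4500 nM.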

Compound 3, concentration for 50% growth inhibition: 200 nM
Estimate against measurement, compound 3: 7.5-fold (0.88 log units) above, outside the stated range (below it).
By their numbers in this assay, from the lowest: compound 3; then compound 2; then compound 1.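

In this assay the exchange of amino for chloro on the aromatic carbon between two ring nitrogen atoms gives a 26-fold lower number from compound 1 to compound 3 (1.41 log units; beyond the scatter) and so shows that this position strongly affects growth inhibition. Among these compounds, this is the first single-place step measured at this position, and it is a large one. No measurement offered here bears on the cause of the step. Going by these compounds, whether a fluoro, a methoxy or a methylamino group at this position would give a number nearer compound 3 or compound 1 remains open.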